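The source may report more compounds than this note shows. Statements on the series, on what has been measured and on what is new or still open speak of the compounds shown alone.

Compound 1 `CC(C)(C)c1cc(-c2cc(=O)c3ccc(OCc4ccc(Cl)cc4)cc3o2)cc(C(C)(C)C)c1O`: 7000 nM
Compound 2 `CCOC(=O)COc1ccc2c(=O)cc(-c3cc(C(C)(C)C)c(O)c(C(C)(C)C)c3)oc2c1`: 3000 nM
Compound 3 `CC(C)(C)c1cc(-c2cc(=O)c3ccc(OCC(=O)N4CCCCC4)cc3o2)cc(C(C)(C)C)c1O`: 3000 nM

In a functional assay for inhibition (a higher number here means a weaker inhibitor, a lower number a stronger inhibitor), compound 1 has the highest number of the three measured compounds, so among them it is the weakest inhibitor. Compound 4 `CCOC(=O)C(C)(C)Oc1ccc2c(=O)cc(-c3cc(C(C)(C)C)c(O)c(C(C)(C)C)c3)oc2c1` has not yet been measured. It differs from compound 1 in one place: 1-(ethoxycarbonyl)-1-methylethyl in place of 4-chlorobenzyl on an oxygen on an aromatic ring. The measured step that bears most directly on this is a 2.3-fold lower number from compound 1 to compound 2 (0.37 log units; beyond the scatter), where an ethoxycarbonyl group likewise enters in place of 4-chlorophenyl; the parallel step a 2.3-fold lower number from compound 1 to compound 3 (0.37 log units; beyond the scatter) is of the same size. The remaining difference between compound 2 and compound 4 is not covered by any measured pair. A modest lowering of the number is therefore expected, a 2.2-fold lower number from compound 1 to compound 4 (0.34 log units; beyond the scatter). Compound 4 is expected to give 3200 nM, with a range from 1400 nM to 7500 nM.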

Compound 4, half-maximal inhibitory concentration: 3000 nM
For compound 4 the middle estimate is 1.1-fold (0.03 log units) above the measured one; the range from low to high includes it.
By their numbers in this assay, from the lowest: compounds 2, 3 and 4 (each within the scatter of the next); then compound 1.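

In this assay, the step of a 2.3-fold lower number from compound 1 to compound 4 (0.37 log units; beyond the scatter) shows that 1-(ethoxycarbonyl)-1-methylethyl on the oxygen on the aromatic ring also gives a lower number than 4-chlorobenzyl, as the two unbranched groups did. Branching the chain carbon that carries the ester leaves the number in place: the comparison with the unbranched ester gives no change at the digits printed from compound 2 to compound 4 (within the scatter) and the comparison with the piperidine amide gives no change at the digits printed from compound 3 to compound 4 (within the scatter) within the same scatter. No supporting measurement explains this flat result. Going by these compounds, whether a free carboxylic acid in place of the ethyl ester, or a longer chain carrying the carbonyl, would shift the number remains open.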